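From ethoxycarbonyl to hydroxymethyl in a cytotoxicity test

This account rests on a few compounds, and the source may have more. Where it says the series, first, only, none or still open, it means among the compounds named here.

- Compound 1 `COc1cc([C@@H]2C[C@@]2(CO)C(=O)Nc2ccccc2)cc(OC)c1OC` gives 86400 nM
- Compound 2 `CCOC(=O)[C@]1(C(=O)Nc2ccccc2)C[C@H]1c1cc(OC)c(OC)c(OC)c1` gives > 100000 nM

Both values come from a functional assay on HeLa cells (Homo sapiens) for cytotoxicity, read by MTT assay, with a stated time of 48 h (a higher number here means a weaker inhibitor, a lower number a stronger inhibitor), and describe weak effects on the cells. Compound 2 stands at > 100000 nM as a limit of the assay, not a number. Compound 3 `COc1cc([C@@H]2C[C@]2(CO)C(=O)Nc2ccccc2)cc(OC)c1OC` has not yet been measured. It departs from compound 2 by one change, hydroxymethyl in place of ethoxycarbonyl on a saturated ring carbon, counted as hydroxymethyl in place of ethoxycarbonyl on a saturated ring carbon in full. Compound 1 also carries hydroxymethyl on that ring carbon and gives 86400 nM as a true number, so a small move towards stronger inhibition in this assay is expected. Compound 3 may yet report only a limit. The estimated change is modest, an at least 1.4-fold lower number from compound 2 to compound 3 (0.15 log units; that floor lies within the scatter) in size. Compound 3 is expected at 70000 nM with an estimated range of 25000 nM to 130000 nM for its measurement.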

Compound 3, half-maximal inhibitory concentration: 32000 nM
Compound 3: middle estimate off by 2.2-fold (0.34 log units), on the high side; the range from low to high includes it.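

In this assay, hydroxymethyl in place of ethoxycarbonyl on a saturated ring carbon gives an at least 3.1-fold lower number from compound 2 to compound 3 (0.49 log units; beyond the scatter), a step that can be read only as a bound: the limit of > 100000 nM in this assay, at which 1 of the 3 values shown sits. The drawn configuration at this ring carbon also matters, with a 2.7-fold lower number from compound 1 to compound 3 (0.43 log units; beyond the scatter): the fact that compounds 1 and 3 differ only in the configuration as drawn. Hydroxymethyl at this position therefore does not fix a single value, since the group and its configuration each carry a step beyond the scatter, and the effect on the cells remains weak throughout.

The compounds shown leave open how an aminomethyl group, a carboxylic acid or a longer hydroxyalkyl chain on this ring carbon would read in this assay. They also give no cause for either step and do not show how the compounds act on the cells.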